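This account rests on a few compounds, and the source may have more. Where it says the series, first, only, none or still open, it means among the compounds named here.

Measured compounds:
compound 1, `CCOC(=O)c1ccc(NC(=O)N2CC2C#N)cc1`, with 7700 nM
compound 2, `N#CC1CN1C(=O)Nc1ccc(Cl)cc1Cl`, with 35000 nM
compound 3, `CCCCNC(=O)N1CC1C#N`, with 12000 nM

These three share a small core with a nitrile and a urea, and each was tested in a functional assay on OVCAR-3 cells (Homo sapiens) for inhibition; a higher number here means a weaker inhibitor, a lower number a stronger inhibitor. Compound 3 sits with compound 1, whose number is within the scatter of its own, while compound 2 gives a clearly higher number, so compound 2 is the weaker inhibitor of that pair. Compound 4, `CNC(=O)N1CC1C#N`, is not yet measured; it differs from compound 3 by hydrogen in place of propyl on a saturated chain carbon bound to an amide-type nitrogen. Among the measured compounds shown here, since no measured pair shows this kind of change, the step from compound 3 to compound 4 is estimated as small, toward a higher number, at the edge of the scatter: a 1.7-fold higher number from compound 3 to compound 4 (0.22 log units; within the scatter). For compound 4 the estimate is 20000 nM, between 8000 nM and 50000 nM.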

Compound 4, half-maximal inhibitory concentration: 14000 nM
The estimate for compound 4 lay 1.4-fold (0.15 log units) above the measured number, and the stated range covers the measured number.
By their numbers in this assay, from the lowest: compounds 1, 3 and 4 (each within the scatter of the next); then compound 2.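

Among the compounds shown here, replacing the butyl chain of compound 3 with the methyl of compound 4 is the first change in this set made in one place only, and this assay reads it as a 1.2-fold higher number from compound 3 to compound 4 (0.07 log units; within the scatter), a step within the scatter. At this position, then, these two chain lengths cannot be told apart in this assay. Nothing measured here gives a reason for this result. Still open, from the compounds shown here alone, is how a chain longer than butyl would read at this place, and whether an amine or a carboxylic acid on the chain would give a number beyond the scatter.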